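The source may report more compounds than this note shows. Statements on the series, on what has been measured and on what is new or still open speak of the compounds shown alone.

Compound 1 `COc1cc(CNC(=O)/C=C/c2ccccc2OCc2nc(C)c(C)nc2C)ccc1O` gives in a functional assay on SH-SY5Y cells (Homo sapiens) for cytotoxicity, read by MTT assay, with stated times of 24 h and 4 h (on this read-out higher numbers stand for an effect only at larger amounts of compound and lower numbers for an effect already at smaller amounts), a value of 12000 nM. Compound 2 `COc1cc(CNC(=O)/C=C/c2ccc(OCc3nc(C)c(C)nc3C)cc2)ccc1O` gives 5370 nM. Compound 3 `COc1cc(CNC(=O)/C=C/c2ccc(OCc3nc(C)c(C)nc3C)c(OC)c2)ccc1O` gives 10200 nM.

Compound 3 stands second highest of the three numbers, nearest to compound 1 and furthest from compound 2, both gaps within the scatter; the step of a 1.9-fold higher number from compound 2 to compound 3 (0.28 log units; within the scatter) is likewise within the scatter. Compound 4 `COc1cc(/C=C/C(=O)NCc2ccc(OCc3nc(C)c(C)nc3C)c(OC)c2)ccc1OCc1nc(C)c(C)nc1C` differs from compound 3 by (3,5,6-trimethylpyrazin-2-yl)methyl in place of hydrogen on an oxygen on an aromatic ring. For the measured compounds named here, no measured step covers such a change: the only measured step concerns a methoxy on an aromatic carbon and does not bear on it. With nothing to lean on, the expected step is a 1.0-fold lower number from compound 3 to compound 4 (0.01 log units; within the scatter), none beyond the scatter. Compound 4 is therefore estimated at 10000 nM in this assay, within the range 3000 nM to 35000 nM.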

Compound 4, half-maximal effective concentration: 11100 nM
Compound 4: the middle estimate sits 1.1-fold (0.05 log units) below what was measured, within the range that was stated.
By their numbers in this assay, from the lowest: compounds 2, 3, 4 and 1 (each within the scatter of the next, the first and the last beyond it).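

In this assay, replacing the hydroxy on the aromatic ring with (3,5,6-trimethylpyrazin-2-yl)methoxy gives a 1.1-fold higher number from compound 3 to compound 4 (0.04 log units; within the scatter), so the read-out does not move beyond the scatter when this oxygen carries the group. The earlier compounds shown here all held a free hydroxy here and so gave no reading of any substitution at this oxygen. Nothing available explains why the number holds.

Still open, on these data alone, is whether a 2-aminoethyl chain or a carboxymethyl group on this oxygen would read the same in this assay.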